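A few compounds are considered here, and "the series" means these few. Any claim that something is new, unique, unknown or untested is made for them only; others in the source may bear on it.

Working notes on the series.

Compound 1 `Cc1cccc(-n2cc(COc3ccc4c(c3)CCC4)nn2)c1` and compound 2 `c1ccc(-n2cc(COc3ccc4c(c3)CCC4)nn2)cc1` share one core and differ only at the outer aromatic ring. In an ADME assay on HEK293 cells (Homo sapiens) for inhibition, read by MTT assay, with a stated time of 48 h, tested at 25 uM (on this read-out lower numbers stand for less inhibition and higher numbers for more inhibition at the one concentration tested (going by the name of the read-out)), compound 1 gives 23.4% and compound 2 gives 23.4%; the step of no change at the digits printed from compound 1 to compound 2 (within the scatter) shows that hydrogen in place of methyl on an aromatic carbon leaves the read-out unchanged within the scatter.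

Compound 3 `Brc1cccc(-n2cc(COc3ccc4c(c3)CCC4)nn2)c1` carries a bromine on the same outer ring. In this assay compound 3 has "not determined" (no result reported), so there is no number for it, and it cannot be placed on the scale spanned by compound 1 and compound 2.

Compound 4 `Brc1ccccc1-n1cc(COc2ccc3c(c2)CCC3)nn1` is the next member. The change from compound 3 is 2-bromophenyl in place of 3-bromophenyl on an aromatic nitrogen. Within the data shown here, the only step measured on this assay is the one from compound 1 to compound 2, and it concerns a methyl, not the move of a bromine, so no measured step bears directly on this change; it shows only that a small change at the outer ring left the number level within the scatter. No step beyond the scatter is therefore expected in this assay. The estimated value for compound 4 in this assay is 24%, with a range from 10% to 40%.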

Compound 4, a percentage reported as inhibition, at one concentration (the size of the read-out at that concentration, not a potency): 16.5%
The estimate for compound 4 lay 7.5 percentage points above the measured number; the range from low to high includes it.
By their numbers in this assay, from the lowest: compounds 4, 1 and 2 (each within the scatter of the next).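

In this assay the result gives a reading for a bromine on the outer ring, attached through that ring to an aromatic nitrogen of the five-membered aromatic ring with 3 nitrogen: bromo in place of hydrogen gives a number 6.9 percentage points lower from compound 2 to compound 4 (within the scatter) and 2-bromophenyl in place of 3-methylphenyl gives a number 6.9 percentage points lower from compound 1 to compound 4 (within the scatter) as the second comparison. The earlier compounds shown here showed only that hydrogen in place of methyl left the number unchanged within the scatter, whereas these steps extend that picture to a 2-bromophenyl, so compound 1, compound 2 and compound 4 all stand within the scatter of one another at the one concentration tested. Nothing measured here bears on why these numbers stand as they do.

Compound 3 has no number, so the move of the bromine from 3-bromophenyl to 2-bromophenyl cannot be read, and any step involving compound 3 stays unread. On these data alone, whether an amine or a carboxylic acid on the outer ring, or a longer chain in place of the bromine, would give a step beyond the scatter remains open.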